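The source may hold more compounds than are shown below. What is called first, only, known or untested is meant among the compounds shown, and "the series" means these compounds.

Measured so far in a functional assay on A549 cells (Homo sapiens) for antiproliferative activity, read by MTT assay; on this read-out higher numbers stand for weaker inhibition and lower numbers for stronger inhibition
- compound 1 `Cc1c(-n2cc(COc3ccc(/C=C/C(=O)c4ccc5c(c4O)CCC(C)(C)O5)cc3)nn2)cccc1[N+](=O)[O-]` gives "not active" (no number reported)
- compound 2 `COc1ccc(-n2cc(COc3ccc(/C=C/C(=O)c4ccc5c(c4O)CCC(C)(C)O5)cc3)nn2)c([N+](=O)[O-])c1` gives "not active" (no number reported)
- compound 3 `CC(=O)c1ccc(-n2cc(COc3ccc(/C=C/C(=O)c4ccc5c(c4O)CCC(C)(C)O5)cc3)nn2)cc1` gives 149000 nM as the only number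

Compound 3 thus stands alone on the numbers shown, and compounds 1 and 2 offer no number to compare it with. Compound 4 `Cc1ccc(-n2cc(COc3ccc(/C=C/C(=O)c4ccc5c(c4O)CCC(C)(C)O5)cc3)nn2)cc1Br` has 3-bromo-4-methylphenyl in place of 4-acetylphenyl on an aromatic nitrogen of a five-membered aromatic ring with 3 nitrogen 3-bromo-4-methylphenyl in place of 4-acetylphenyl on an aromatic nitrogen in the count. Within the data shown here, no step between measured compounds is available to size this change, so no shift beyond the scatter is expected in this assay and no direction is favoured. The expected 1.1-fold lower number from compound 3 to compound 4 (0.06 log units; within the scatter) is small. A result without a number also remains possible. The estimate for compound 4 is 130000 nM within an expected range of 45000 nM to 350000 nM for now.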

Compound 4, half-maximal inhibitory concentration: "not active" (no number reported)
For compound 4 the study gives words and no number; there is nothing to compare the estimate with.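

Among these compounds, compound 4 carries no number in this assay, and no step from compound 3 to compound 4 can be read. No supporting data bear on this result. The compounds shown leave open how the group on the aromatic nitrogen relates to activity.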